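This account rests on a few compounds, and the source may have more. Where it says the series, first, only, none or still open, it means among the compounds named here.

Three compounds built on one shared core have been run through an ADME assay on L02 cells (Homo sapiens) for cytotoxicity, read by MTT assay, with a stated time of 48 h; on this read-out lower numbers stand for stronger inhibition and higher numbers for weaker inhibition. Compound 1 `Cc1ccc2[nH]c(=O)c(-c3nc4cc([N+](=O)[O-])ccc4[nH]3)cc2c1` gives > 100000 nM, a limit of the assay rather than a number. Compound 3 `O=c1[nH]c2ccccc2cc1-c1nc2cc(Br)ccc2[nH]1` likewise returns only the limit > 100000 nM. Compound 2 `COc1ccc2[nH]c(=O)c(-c3nc4cc(F)ccc4[nH]3)cc2c1` sits at the same limit, > 100000 nM. Compound 2 thus stands where every value shown stands, at the limit of > 100000 nM in this assay, at which 3 of the 3 values shown sit. Compound 4 `COc1ccc2[nH]c(=O)c(-c3nc4ccccc4[nH]3)cc2c1` is not yet measured. It differs from compound 2 by hydrogen in place of fluoro on an aromatic carbon. Going by the values given here, no measured step between compounds differing in one place is available, so no shift beyond the scatter is expected in this assay. Compound 4 is expected to give 150000 nM, within 60000 nM to 400000 nM. The expected step is a step that the limit leaves unreadable from compound 2 to compound 4, most likely reported again as a limit.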

Compound 4, half-maximal inhibitory concentration: > 100000 nM
Compound 4: a limit, no number; the forecaster's own chance of this, stated with the estimate: 85%; the middle value does not contradict the limit.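

Going by these compounds alone, compound 2 and compound 4 each return only a limit in this assay, so no step between them can be read. The compounds shown leave open whether hydrogen in place of fluoro on an aromatic carbon changes the read-out at all.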